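The compounds below may be only part of what the source reports. "The series", "measured", "known", "first", "only" and "open" are said of these compounds alone.

Values in an ADME assay (liver) for metabolic stability, with Liver microsome (Rattus norvegicus) as the target, using microsomes and NADPH, with a stated time of 30 min (a higher number here means faster removal of the compound, a lower number slower removal), so far:

compound 1 `CC#C[C@H]1CN(S(=O)(=O)c2ccc(N)nc2)CCN1c1ccc(S(=O)(=O)Nc2ccccc2)cc1` gives > 399 mL.min-1.g-1 (a limit of the assay, not a number)
compound 2 `CC#C[C@H]1CN(S(=O)(=O)c2ccc(N)nc2)CCN1c1ccc(C(O)(COC)C(F)(F)F)cc1` gives 93 mL.min-1.g-1 (a number)
compound 3 `CC#C[C@H]1CN(S(=O)(=O)c2ccc(N)nc2)CCN1c1ccc(C(C)=O)cc1` gives 249 mL.min-1.g-1 (a number)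

Compound 3 holds the higher of the two actual numbers, and compound 1 stands apart with its limit. The nearest number is that of compound 2, set by a 2.7-fold higher number from compound 2 to compound 3 (0.43 log units; beyond the scatter) as the measured gap.

The next change leads to compound 4 `CC#C[C@H]1CN(S(=O)(=O)c2ccc(N)nc2)CCN1c1ccc(S(=N)(=O)C2CC2)cc1` and is described by a group of 6 heavy atoms (3 carbon, 1 nitrogen, 1 oxygen, 1 sulfur; one three-membered non-aromatic ring of carbon only) in place of a group of 3 heavy atoms (2 carbon, 1 oxygen; no ring), on an aromatic carbon as the acetyl leaves that aromatic carbon, para to a large group.

Within the data shown here, three measured steps concern the same place: an at least 4.2-fold lower number from compound 1 to compound 2 (0.63 log units; beyond the scatter) and an at least 1.6-fold lower number from compound 1 to compound 3 (0.20 log units; that floor lies within the scatter) and a 2.7-fold higher number from compound 2 to compound 3 (0.43 log units; beyond the scatter) are all there is. None of them involves the entering group. The step from the limit gives only a floor and sets no size. The one replacement of acetyl with two actual numbers is compound 2, so the reasoning rests on a 2.7-fold higher number from compound 2 to compound 3 (0.43 log units; beyond the scatter) read in reverse. Compound 1 also lacks the acetyl but goes against a general fall.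

A modest fall of similar size is therefore expected in this assay as the estimated 2.1-fold lower number from compound 3 to compound 4 (0.32 log units; beyond the scatter) with wide uncertainty.

For compound 4 the estimate is 120 mL.min-1.g-1 with an expected range of 50 mL.min-1.g-1 to 280 mL.min-1.g-1 in this series.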

Compound 4, intrinsic clearance in microsomes: 23 mL.min-1.g-1
Beside the measured number, compound 4's estimate is 5.2-fold (0.72 log units) above it; the measured number lies below the stated range.
By their numbers in this assay, from the lowest: compound 4; then compound 2; then compound 3. At a limit, above all of these: compound 1.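

In this assay, among these compounds, this place on an aromatic carbon, para to a large group, proves able to move the number much further than the earlier compounds showed: exchanging acetyl for the entering group, with its three-membered non-aromatic ring, gives an 11-fold lower number from compound 3 to compound 4 (1.03 log units; beyond the scatter), the largest step between two actual numbers. The same group also clears the previous lowest value, with a 4.0-fold lower number from compound 2 to compound 4 (0.61 log units; beyond the scatter), so compound 4 now has the lowest number in this assay, and the removal rate at this place is clearly not bounded by the value of compound 2. Compound 1 carries a limit of the assay and not a number, so an at least 17-fold lower number from compound 1 to compound 4 (1.23 log units; beyond the scatter) fixes only a floor on that step, whose true size stays unknown: the limit of > 399 mL.min-1.g-1 in this assay, at which 1 of the 4 values shown sits.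

The three-membered ring and the sulfur-centred part of the entering group change together, so these compounds do not show which of them accounts for the fall. Going by these compounds, it also remains open whether a plain methyl on that sulfur in place of the ring, or an amine or a carboxylic acid at this place, would keep the number near that of compound 4.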